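The compounds below may be only part of what the source reports. "The series", "measured", "known", "first", "only" and "open" are said of these compounds alone.

Values so far in a functional assay on P388 cells (Mus musculus) for cytotoxicity; on this read-out lower numbers stand for stronger inhibition and higher numbers for weaker inhibition:
- compound 1 `COc1ccc(C[C@H]2C(=O)N[C@@H](C)C(=O)N(C)[C@H]3Cc4ccc(cc4)Oc4cc(ccc4OC)C[C@@H](C(=O)N[C@H](C)C(=O)N[C@@H](CSC(C)=O)C(=O)N2C)N(C)C3=O)cc1` gives 9.77 nM
- compound 2 `COc1ccc(C[C@H]2C(=O)N[C@@H](C)C(=O)N(C)[C@H]3Cc4ccc(cc4)Oc4cc(ccc4OC)C[C@@H](C(=O)N[C@H](C)C(=O)N[C@@H](CCSC)C(=O)N2C)N(C)C3=O)cc1` gives 20.4 nM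
- compound 3 `CCCCN1C(=O)[C@@H](C)NC(=O)[C@@H]2Cc3ccc(OC)c(c3)Oc3ccc(cc3)C[C@@H](C(=O)N2C)N(C)C(=O)[C@H](C)NC(=O)[C@H](Cc2ccc(OC)cc2)N(C)C(=O)[C@@H]1C` gives 12 nM

Compound 3 at 12 nM lies within the scatter of both compound 1 and compound 2, so it takes no rank of its own. Compound 4 `CC/C=C/CN1C(=O)[C@@H](C)NC(=O)[C@@H]2Cc3ccc(OC)c(c3)Oc3ccc(cc3)C[C@@H](C(=O)N2C)N(C)C(=O)[C@H](C)NC(=O)[C@H](Cc2ccc(OC)cc2)N(C)C(=O)[C@@H]1C` carries but-1-en-1-yl in place of propyl on a saturated chain carbon bound to an amide-type nitrogen in a ring. Among the measured compounds shown here, the only measured step is a 2.1-fold higher number from compound 1 to compound 2 (0.32 log units; beyond the scatter) and it is modest. For the measured compounds named here, that step involves other groups at another place, so it offers only a rough scale, and no measured step covers this change. In this assay the estimate is a 1.1-fold higher number from compound 3 to compound 4 (0.03 log units; within the scatter) and so no step beyond the scatter is expected. Compound 4 is expected at 13 nM (estimated range 6 nM to 28 nM).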

Compound 4, half-maximal inhibitory concentration: 12 nM
For compound 4 the middle estimate is 1.1-fold (0.03 log units) above the measured one, within the range that was stated.
By their numbers in this assay, from the lowest: compounds 1, 3, 4 and 2 (each within the scatter of the next, the first and the last beyond it).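

In this assay the step reads no change at the digits printed from compound 3 to compound 4 (within the scatter), the first read at this position, since the earlier step lay at another place. On a saturated chain carbon bound to an amide-type nitrogen in a ring, but-1-en-1-yl and propyl therefore cannot be told apart on this read-out, and a double bond outside aromatic rings is accepted here. No evidence at hand explains this result.

On these data alone, whether a saturated pentyl chain would read the same remains open. So does the outcome with an amine or a carboxylic acid at this place.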